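The compounds below may be only part of what the source reports. "The series", "measured", "known", "first", "only" and "open" are said of these compounds alone.

Compound 1 `CC(C)N(Cc1cccc(OCCCCCC(=O)O)c1)C(=O)c1ccc(-c2cccc3ccccc23)cc1` gives > 26000 nM in an ADME assay on Raji cells (Homo sapiens) for cytotoxicity, read by CellTiter-Glo and resazurin assay, with a stated time of 72 h (a higher number here means that more compound is needed for the effect, a lower number that less compound is needed), a value that is a limit of the assay and not a number. Compound 2 `CC(C)N(Cc1cccc(OCCCCCC(=O)O)c1)C(=O)c1ccc(-c2ccncc2)cc1` gives > 26000 nM in this assay, again a limit of the assay. Compound 3 `CC(C)N(Cc1cccc(OCCCCCC(=O)O)c1)C(=O)c1ccc(-c2cccc(Oc3ccccc3)c2)cc1` gives > 18700 nM in this assay, also a limit of the assay.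

All three measured compounds therefore stand at limits. Compound 3 stands at the lower of the two: the limit of > 18700 nM in this assay, at which 1 of the 3 values shown sits. Compound 1 and compound 2 sit at the other: the limit of > 26000 nM in this assay, at which 2 of the 3 values shown sit. Among the compounds with values here, the only step between measured compounds that differ in one place, a step that the two limits leave unreadable from compound 1 to compound 2, cannot be read, since both of its ends are limits.

Compound 4 `CC(C)N(Cc1cccc(OCCCCCC(=O)O)c1)C(=O)c1ccc(-c2cccc(S(C)(=O)=O)c2)cc1` differs from compound 3 by methylsulfonyl in place of phenoxy on an aromatic carbon. Within the data shown here, no measured step bears directly on this change, and the one step that was recorded gives no size at all. What the numbers do show is that three compounds carrying quite different groups on the same aromatic carbon all remain at limits in this assay. Compound 4 is therefore expected to remain at a limit as well, and the step that the limit leaves unreadable from compound 3 to compound 4 is estimated to be nothing beyond the scatter. For compound 4 the estimate in this assay is 30000 nM, with a range from 10000 nM to 100000 nM.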

Compound 4, half-maximal effective concentration: > 26000 nM
Compound 4: no number, only a limit; the forecaster's own chance of this, stated with the estimate: 85%; the middle value is on the limit's open side.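

The steps from compound 1, compound 2 and compound 3 to compound 4 cannot be read, as both ends of each are limits of the assay and not numbers. The compounds shown leave open what concentration any of them needs for the effect in this assay, and whether the different groups on this aromatic carbon change it at all.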